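The compounds below may be only part of what the source reports. "The series", "measured", "known", "first", "only" and "open" are said of these compounds alone.

Measured in a functional assay on CCRF-CEM cells (Homo sapiens), read by MTT assay, with a stated time of 72 h; on this read-out higher numbers stand for weaker inhibition and lower numbers for stronger inhibition:
- compound 1 `COc1ncnc2c1c(-c1ccccc1)cn2[C@@H]1O[C@H](CO)[C@@H](O)[C@H]1O`: > 20000 nM (limit)
- compound 2 `O=c1[nH]cnc2c1c(-c1ccccc1)cn2[C@@H]1O[C@H](CO)[C@@H](O)[C@H]1O`: > 100000 nM (limit)
- compound 3 `O=c1[nH]cnc2c1c(-c1cc3ccccc3o1)cn2[C@@H]1O[C@H](CO)[C@@H](O)[C@H]1O`: > 20000 nM (limit)

Compound 3 reads > 20000 nM, which is a limit and not a number. The other two compounds also give only limits, so the series has no measured number yet.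

Compound 4 `Nc1nc2c(c(-c3cc4ccccc4o3)cn2[C@@H]2O[C@H](CO)[C@@H](O)[C@H]2O)c(=O)[nH]1` differs from compound 3 by amino in place of hydrogen on an aromatic carbon, between two ring nitrogen atoms.

Among the compounds with values here, no measured step covers this change. Within the data shown here, the only step available, a step that the two limits leave unreadable from compound 2 to compound 3, is a change elsewhere in the molecule, and its size cannot be read. The estimate therefore rests on the three limits alone, and no gain in this assay can be derived from them. No clear shift in either direction is expected, and the expected step is a step that the limit leaves unreadable from compound 3 to compound 4. A further limit is the likeliest result.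

For compound 4 the estimated value is 40000 nM, with an expected range of 10000 nM to 100000 nM.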

Compound 4, half-maximal inhibitory concentration: > 20000 nM
Compound 4 ended at the assay's limit; the forecaster's own chance of this, stated with the estimate: 70%; the middle value does not contradict the limit.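

In this assay compound 3 gives > 20000 nM, a limit. Compound 4 gives > 20000 nM, also a limit, so the step from one to the other cannot be read. The compounds shown leave open what amino in place of hydrogen does to inhibition in this assay, since none yet has a measured number.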